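Adding a Methoxy Group to Compound 3

The source may report more compounds than this note shows. Statements on the series, on what has been measured and on what is new or still open speak of the compounds shown alone.

In a functional assay on MRC5 cells (Homo sapiens) for cytotoxicity, read by colorimetric assay and MTT assay (a lower number here means that less compound is tolerated, a higher number that more compound is tolerated), compound 1 (`CCN(CC)c1ccc(/C=N/NC(=O)c2ccc([N+](=O)[O-])cc2)c(O)c1`) gives 2500 nM as its reading. Compound 2 (`CCN(CC)c1ccc(/C=N/NC(=O)c2ccc(C(C)(C)C)cc2)c(O)c1`) gives 1100 nM on the same scale. Compound 3 (`CC(C)(C)c1ccc(O)c(/C=N/NC(=O)c2ccccc2)c1`) gives 2600 nM and so stands level with compound 1, with compound 2 clearly lower. Compound 4 (`COc1ccc(C(=O)N/N=C/c2cc(C(C)(C)C)ccc2O)cc1`) has not been measured yet. It differs from compound 3 by a single change (methoxy in place of hydrogen on an aromatic carbon), methoxy in place of hydrogen on an aromatic carbon, which also reads as phenyl to 4-methoxyphenyl. Within the data shown here, only one measured step offers any guide, namely a 2.3-fold lower number from compound 1 to compound 2 (0.36 log units; beyond the scatter) when tert-butyl takes the place of nitro on an aromatic carbon. Among the measured compounds shown here, that step is modest, it involves different groups in a different pair, and no measured compound carries a methoxy. No change beyond the scatter is therefore expected, and a small shift in either direction would be unsurprising. The expected step is a 1.2-fold lower number from compound 3 to compound 4 (0.07 log units; within the scatter) on this estimate. Compound 4 is estimated at 2200 nM within a range of 1000 nM to 4800 nM for now.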

Compound 4, half-maximal cytotoxic concentration: > 100000 nM
Compound 4 ended at the assay's limit (the forecaster's own chance of this, stated with the estimate: 3%); middle value at least 45-fold (1.65 log units) from the limit.
By their numbers in this assay, from the lowest: compound 2; then compounds 1 and 3 (each within the scatter of the next). At a limit, above all of these: compound 4.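

Swapping hydrogen for methoxy, para to a large group on a six-membered aromatic ring of carbon only, gives an at least 38-fold higher number from compound 3 to compound 4 (1.58 log units; beyond the scatter) and shows that this position can respond strongly to an addition of just 2 heavy atoms. Among these compounds, the only earlier step, a 2.3-fold lower number from compound 1 to compound 2 (0.36 log units; beyond the scatter), was far smaller and gave no sign that one change could move the number so much. Compound 4 gives > 100000 nM, which is a limit of the assay and not a number, so the full size of the step stays unknown: the limit of > 100000 nM in this assay, at which 1 of the 4 values shown sits.

Going by these compounds, it remains open whether an amine, a carboxylic acid or a longer chain such as butoxy at this position would shift the reading in this assay as far as methoxy does. Also open, on these data alone, is whether methoxy would have the same effect on the diethylamino-bearing core of compound 1 and compound 2.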